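This account rests on a few compounds, and the source may have more. Where it says the series, first, only, none or still open, it means among the compounds named here.

In a functional assay on PC-3 cells (Homo sapiens) for inhibition, read by sulforhodamine B assay, with a stated time of 48 h, tested at 0.01 uM (a higher number here means a weaker effect of the compound at the concentration tested, a lower number a stronger effect), compound 1 `O=C(Nc1cccc(-n2cc(-c3ccncc3)c(-c3cc(O)cc(Cl)c3)n2)c1)Nc1ccc(Cl)c(Cl)c1` gives 90%, and compound 2 `COc1cc(Cl)cc(-c2nn(-c3cccc(NC(=O)Nc4ccc(Cl)c(Cl)c4)c3)cc2-c2ccncc2)c1` gives 96%. Among the compounds with values here, the one measured step, a number 6 percentage points higher from compound 1 to compound 2 (within the scatter), leaves compound 2 with the highest of the two numbers, though its nearest neighbour, compound 1, sits within the scatter of it. Compound 3 `COc1cc(Cl)cc(-c2nn(-c3cccc(NC(=O)c4cccc(C(F)(F)F)c4)c3)cc2-c2ccncc2)c1` is not yet measured in this assay; it differs from compound 2 by 3-(trifluoromethyl)phenyl in place of (3,4-dichlorophenyl)amino on a carbonyl carbon. Within the data shown here, no measured step touches the carbonyl carbon or the groups on it, so the data give no guidance on how large this change might be; the only step recorded, at the oxygen on the aromatic ring, stayed within the scatter. For compound 3 the estimate in this assay is therefore 93%, with a range of 78% to 105%. This means an expected step of a number 3 percentage points lower from compound 2 to compound 3 (within the scatter), which is expected to remain within the scatter, with the range widened to admit a larger change.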

Compound 3, a percentage reported as activity, at one concentration (the size of the read-out at that concentration, not a potency): 94%
Compound 3: middle estimate off by 1 percentage points, on the low side; measured number inside the range.
By their numbers in this assay, from the lowest: compounds 1, 3 and 2 (each within the scatter of the next).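

In this assay, within the data shown here, the change at the carbonyl carbon gives a number 2 percentage points lower from compound 2 to compound 3 (within the scatter), the first look at this position. Replacing (3,4-dichlorophenyl)amino with 3-(trifluoromethyl)phenyl removes the hydrogen-bond donor counted in the leaving group and swaps two chlorine atoms for three fluorine atoms, yet the read-out does not move beyond the scatter at the one concentration tested. No supporting data bear on why this exchange leaves the number within the scatter.

On these data alone, it remains open whether a smaller or differently built group on the carbonyl carbon, such as methyl, a morpholine or a benzoic acid, would shift the number beyond the scatter. As far as these compounds go, it is also open whether compound 2 and compound 3 would separate at a higher concentration.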